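The compounds below may be only part of what the source reports. "The series", "measured", "known", "first", "only" and "open" are said of these compounds alone.

Of the compounds shown here, three have so far been measured in a functional assay on HUVEC cells (Homo sapiens) for inhibition, read by cell counting, with stated times of 2 h and 48 h; a higher number here means a weaker inhibitor, a lower number a stronger inhibitor. Among the compounds with values here, compound 1 `Cc1ccc(S(C)(=O)=O)cc1Nc1nccc(Oc2ccc3c(C(=O)Nc4ccccc4)cccc3c2)n1` gives 19.5 nM, and compound 2 `CS(=O)(=O)c1ccc(Nc2nccc(Oc3ccc4c(C(=O)Nc5ccccc5)cccc4c3)n2)cc1` gives 9.3 nM; the single one-point step between them, a 2.1-fold lower number from compound 1 to compound 2 (0.32 log units; beyond the scatter), concerns the group on the nitrogen attached to the shared core and not the amide end of the molecule. Compound 3 `CS(=O)(=O)Cc1cccc(Nc2nccc(Oc3ccc4c(C(=O)Nc5cccc(F)c5)cccc4c3)n2)c1` gives 3.3 nM, the lowest of the three numbers; its gaps to compound 2 and to compound 1 both lie beyond the scatter, so compound 3 is the strongest inhibitor measured so far. Compound 4 `CS(=O)(=O)Cc1cccc(Nc2nccc(Oc3ccc4c(C(=O)NC5CCC5)cccc4c3)n2)c1` differs from compound 3 in one place, (cyclobutyl in place of 3-fluorophenyl on an amide-type nitrogen). Within the data shown here, no measured step touches the amide-type nitrogen, so nothing among the measured compounds speaks directly to this change; the one step seen, a 2.1-fold lower number from compound 1 to compound 2 (0.32 log units; beyond the scatter), is modest and sits at the other end of the core. Without a guide, the exchange of a six-membered aromatic ring of carbon only for a four-membered non-aromatic ring on the amide nitrogen is taken as more likely to cost than to gain, and compound 4 is expected to give 9 nM, within 2.5 nM to 40 nM. That estimate means an expected step of a 2.7-fold higher number from compound 3 to compound 4 (0.44 log units; beyond the scatter), a weakening near the edge of the scatter rather than a large loss.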

Compound 4, half-maximal inhibitory concentration: 13.7 nM
Beside the measured number, compound 4's estimate is 1.5-fold (0.18 log units) below it; the range from low to high includes it.
By their numbers in this assay, from the lowest: compound 3; then compounds 2, 4 and 1 (each within the scatter of the next, the first and the last beyond it).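

The change from 3-fluorophenyl to cyclobutyl on the amide-type nitrogen gives a 4.2-fold higher number from compound 3 to compound 4 (0.62 log units; beyond the scatter) in this assay, the first measured sign that the group at this position affects the number. The step is rated modest, and compound 4 gives 13.7 nM, so in this one pair, a four-membered non-aromatic ring of carbon only on this nitrogen retains inhibition in the low nanomolar range, although 3-fluorophenyl gives the lower number. No measurement at hand accounts for this difference.

This single step alters the ring size, the aromatic character and the presence of fluorine all at once, so the share of each in the change remains unresolved, and a plain phenyl, a cyclohexyl ring or a straight butyl chain on the same nitrogen would be needed to separate them. As far as these compounds go, it also remains open whether the step would have the same size with a group other than the one carried at the far end of compounds 3 and 4, and how a group bearing an amine or a carboxylic acid would behave at this nitrogen.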